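Methoxy in Place of Methyl: What Compound 4 Might Give

The source may hold more compounds than are shown below. What is called first, only, known or untested is meant among the compounds shown, and "the series" means these compounds.

Compound 1, `Cc1ccc(/C=C(/C#N)C(=O)c2ccc[nH]2)cc1`: in a functional assay on BE(2)-C cells (Homo sapiens) for cytotoxicity, read by MTT assay, with a stated time of 72 h (on this read-out higher numbers stand for weaker inhibition of growth and lower numbers for stronger inhibition of growth), compound 1 gives 11000 nM.
Compound 2, `N#C/C(=C/c1ccc(Cl)cc1)C(=O)c1ccc[nH]1`: compound 2 gives 63000 nM.
Compound 3, `N#C/C(=C/c1ccc(O)cc1)C(=O)c1ccc[nH]1`: compound 3 gives < 10000 nM, which is a limit of the assay and not a number.

Among the two numbers shown, compound 1 holds the lowest; its nearest neighbour is compound 2, with a 5.7-fold higher number from compound 1 to compound 2 (0.76 log units; beyond the scatter). Compound 3 sits at the limit of < 10000 nM in this assay, at which 1 of the 3 values shown sits, so its value is a limit and not a number.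

Compound 4, `COc1ccc(/C=C(/C#N)C(=O)c2ccc[nH]2)cc1`, differs from compound 1 in one place: methoxy in place of methyl on an aromatic carbon. Two measured steps start from the same place on compound 1. Exchanging the methyl for chloro gave a 5.7-fold higher number from compound 1 to compound 2 (0.76 log units; beyond the scatter), a clear worsening. Exchanging it for hydroxy gave an at least 1.1-fold lower number from compound 1 to compound 3 (0.04 log units; that floor lies within the scatter), a floor that lies within the scatter. The methoxy group shares the oxygen of the hydroxy and the single-carbon size of the methyl, so neither step points to a large move, and a shift within the scatter is expected, as a 1.2-fold lower number from compound 1 to compound 4 (0.09 log units; within the scatter). Compound 4 is therefore estimated at 9000 nM in this assay, with a range from 3000 nM to 30000 nM, and a real chance that only a limit is reported.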

Compound 4, concentration for 50% growth inhibition: < 10000 nM
Compound 4 ended at the assay's limit; the forecaster's own chance of this, stated with the estimate: 45%; the middle value lies beyond the limit too.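

In this assay, methoxy in place of methyl on this aromatic carbon gave an at least 1.1-fold lower number from compound 1 to compound 4 (0.04 log units; that floor lies within the scatter), so this position tolerates the added oxygen without any worsening of the kind chloro brought, although the floor alone does not show a gain over compound 1. Methoxy in place of chloro gave an at least 6.3-fold lower number from compound 2 to compound 4 (0.79 log units; beyond the scatter), which means that compound 2 now has a higher number than each of the other three compounds, with every step to it printed beyond the scatter. Compound 3 and compound 4 both rest on a limit of the assay and not on a number, so the step between them, methyl in place of hydrogen on the oxygen, cannot be read: the limit of < 10000 nM in this assay, at which 2 of the 4 values shown sit.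

The compounds shown leave open how far under that limit the true values of compound 3 and compound 4 lie, and so whether either one really differs from compound 1. They also leave open how an amine, a carboxylic acid or a longer chain such as ethoxy would read at this position on the shared core.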